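The source may hold more compounds than are shown below. What is called first, only, known or untested is meant among the compounds shown, and "the series" means these compounds.

Compound 1 `CCC(=O)N(Cc1ccc(OC)c(O)c1)c1cc(OC)c(OC)c(OC)c1` is the strongest of the three measured compounds in a functional assay on HCT-116 cells (Homo sapiens) for inhibition, read by MTT assay, with a stated time of 48 h (a lower number here means a stronger inhibitor, a higher number a weaker inhibitor), where compound 1 gives 61 nM. The other two compounds lack its propanoyl group and carry instead a secondary amine on the shared core: compound 2 `COc1ccc(CNc2cc(OC)c(OC)c(OC)c2)cc1N` gives 8270 nM in this assay, and compound 3 `COc1ccc(CNc2cc(OC)c(OC)c(OC)c2)cc1Cl` gives 41700 nM in this assay. Among the compounds with values here, the only single-point step among the measured compounds, a 5.0-fold higher number from compound 2 to compound 3 (0.70 log units; beyond the scatter), concerns an aromatic substituent and so says little about a change on the propanoyl chain.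

Compound 4 `COc1ccc(CN(C(=O)C(C)Br)c2cc(OC)c(OC)c(OC)c2)cc1O` differs from compound 1 by one atom: bromo in place of hydrogen on a saturated chain carbon bound to a carbonyl carbon and a saturated chain carbon. Within the data shown here, no measured pair shows what this kind of change does to the number in this assay, so the expectation rests on the size of the change alone: a single added heavy atom at a saturated chain carbon, with no ring, no donor and no acceptor entering. Such a small change is expected to move the number little, and in no direction that the data can indicate. For compound 4 the estimate is therefore 80 nM, with a range from 20 nM to 400 nM, which is an expected step of a 1.3-fold higher number from compound 1 to compound 4 (0.12 log units; within the scatter).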

Compound 4, half-maximal inhibitory concentration: 140 nM
The estimate for compound 4 lay 1.8-fold (0.24 log units) below the measured number, within the range that was stated.
By their numbers in this assay, from the lowest: compound 1; then compound 4; then compound 2; then compound 3.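

In this assay, within the data shown here, the change from propanoyl to (1-bromoethyl)carbonyl gives a 2.3-fold higher number from compound 1 to compound 4 (0.36 log units; beyond the scatter), the first measured step on this saturated chain carbon, whereas the earlier step concerned only an aromatic substituent. This step lies beyond the scatter, so the number does respond to a change at this position, but the step is modest, and the bromo-bearing compound 4 remains a measurable inhibitor at 140 nM. Nothing available accounts for the direction or the size of this step.

On these data alone, whether a fluoro group, a hydroxy group or an amine on this same carbon would raise the number as far, leave it unchanged or lower it remains open, as does the effect of a longer chain in place of the propanoyl group. As far as these compounds go, the contribution of the propanoyl group itself also remains open, as compound 1 differs from compound 2 and from compound 3 in more than one place, so neither comparison isolates that group.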